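The source may hold more compounds than are shown below. What is called first, only, known or untested is meant among the compounds shown, and "the series" means these compounds.

Compound 3 `O=C(O)c1cn(Cc2ccc(-c3ccccc3)cc2)c2ccsc2c1=O` is a carboxylic acid carrying a phenyl group on an outer benzene ring. In an ADME assay on the whole organism (serum) for protein binding, with Homo sapiens as the target, using equilibrium dialysis, compound 3 gives 98.7%. Near the top of this scale, what matters is the small share left free, so gaps that look slight in percent can be large for that free share. Compound 2 `O=C(O)c1cn(Cc2ccc(-c3ccccc3)cc2)c2nccnc2c1=O`, with a different core, gives 97.7%, which lies within the usual scatter of compound 3. Compound 1 `O=C(O)c1cn(Cc2ccc(-n3cccn3)cc2)c2ncccc2c1=O` gives 93.9%, and its free share stands apart from that of compound 3 by more than the scatter.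

Compound 4 `Cn1cc(-c2ccc(Cn3cc(C(=O)O)c(=O)c4sccc43)cc2)cn1` keeps the core of compound 3 and places 1-methyl-1H-pyrazol-4-yl in place of phenyl on an aromatic carbon. Going by the values given here, no pair of measured compounds isolates this swap. The nearest guide is compound 1 at 93.9%, which also has a five-membered aromatic ring with 2 hetero atoms in place of phenyl, but it differs in its core as well, so it offers only a hint. A moderate estimated step a 3.1-fold higher unbound fraction from compound 3 to compound 4 (0.49 log units; beyond the scatter) towards more free compound is expected, probably just beyond the scatter. In this assay compound 4 is expected at 96%, with an estimated range from 92.5% to 98.2%.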

Compound 4, plasma protein binding: 93.4%
Beside the measured number, compound 4's estimate is 1.7-fold (0.22 log units) (unbound fraction) below it; the range from low to high includes it.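

On the core of compound 3, at the aromatic carbon para to a large group, replacing phenyl with 1-methyl-1H-pyrazol-4-yl gives a 5.1-fold higher unbound fraction from compound 3 to compound 4 (0.71 log units; beyond the scatter) in this assay. Going by these compounds alone, this is the first pair that differs in one place only, so this swap can now be read on its own, without a change of core mixed in. Both groups have 6 heavy atoms and no net charge, so the rise in free compound occurs with no change in heavy-atom count; what changes is the ring, from a six-membered aromatic ring of carbon only to a five-membered aromatic ring with 2 hetero atoms and 2 hydrogen-bond acceptors. The data shown offer no measurement that explains why the free share rises with this swap.

Within the data shown here, it remains open whether the same swap would shift binding by a similar amount on the cores of compound 1 or compound 2, since only one core carries this pair. Also open, going by these compounds, is how a pyridine ring, a morpholine or the pyrazole without its methyl group would behave at this position.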